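Three Quinazoline Amides Sit at the Assay Ceiling

A few compounds are considered here, and "the series" means these few. Any claim that something is new, unique, unknown or untested is made for them only; others in the source may bear on it.

Compound 1 `O=C(CN1CCCCC1)Nc1ccc2ncnc(Nc3cccc(C(F)(F)F)c3)c2c1` carries a piperidin-1-yl on a saturated chain carbon bound to a carbonyl carbon. In a functional assay on HepG2 cells (Homo sapiens) for antiproliferative activity, read by MTT assay, with a stated time of 48 h (a lower number here means a stronger inhibitor, a higher number a weaker inhibitor), compound 1 gives only a limit, > 100000 nM. Compound 2 `CN1CCN(CC(=O)Nc2ccc3ncnc(Nc4cccc(C(F)(F)F)c4)c3c2)CC1` differs from it by 4-methylpiperazin-1-yl in place of piperidin-1-yl on a saturated chain carbon bound to a carbonyl carbon. In this assay compound 2 also gives only a limit, > 100000 nM. The resulting step is therefore a step that the two limits leave unreadable from compound 1 to compound 2. Compound 3 `O=C(CN1CCCCC1)Nc1ccc2ncnc(Nc3ccc(Cl)c(C(F)(F)F)c3)c2c1` differs from compound 1 by chloro in place of hydrogen on an aromatic carbon. In this assay compound 3 gives only a limit, > 100000 nM. That step is a step that the two limits leave unreadable from compound 1 to compound 3. Going by the values given here, all of this rests on (the limit of > 100000 nM in this assay, at which 3 of the 3 values shown sit), so no step among the three can be sized.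

Compound 4 `CN1CCN(CC(=O)Nc2ccc3ncnc(Nc4ccc(Cl)c(C(F)(F)F)c4)c3c2)CC1` is not yet measured. Among the compounds with values here, it differs from compound 3 by 4-methylpiperazin-1-yl in place of piperidin-1-yl on a saturated chain carbon bound to a carbonyl carbon, which is the same change, at the same place, as the one from compound 1 to compound 2. Because the step from compound 1 to compound 2 stayed within (the limit of > 100000 nM in this assay, at which 3 of the 3 values shown sit), the change from compound 3 to compound 4 is expected to read as a step that the limit leaves unreadable from compound 3 to compound 4. Compound 4 is expected to give about 150000 nM, within 50000 nM to 500000 nM, most likely again as a limit.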

Compound 4, half-maximal inhibitory concentration: 25300 nM
The estimate for compound 4 lay 5.9-fold (0.77 log units) above the measured number; the measured number lies below the stated range.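

On the core of compound 3, 4-methylpiperazin-1-yl in place of piperidin-1-yl gives an at least 3.9-fold lower number from compound 3 to compound 4 (0.59 log units; beyond the scatter) in this assay, and on the core of compound 2, chloro in place of hydrogen gives an at least 3.9-fold lower number from compound 2 to compound 4 (0.59 log units; beyond the scatter). Together these show that compound 4, with both changes at once, is the only one of the four to give a readable number, so a real drop appears on the chloro-bearing core. They do not show that the change carries from one core to another, since the same change on the core without chloro, from compound 1 to compound 2, cannot be read, and each readable step is only a minimum size: the limit of > 100000 nM in this assay, at which 3 of the 4 values shown sit.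

The compounds shown leave open whether morpholin-4-yl in place of 4-methylpiperazin-1-yl, or bromo in place of chloro, would keep the number that compound 4 gives, 25300 nM. They also leave open whether a longer chain in place of the single saturated chain carbon would preserve this result.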